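Ring-Amide Exchange with Chain Extension in an In Vivo Series

The source may report more compounds than this note shows. Statements on the series, on what has been measured and on what is new or still open speak of the compounds shown alone.

Of the compounds shown here, two have been measured in an in vivo functional assay on the whole organism for inhibition, with Rattus norvegicus as the target; a higher number here means that more compound is needed for the effect, a lower number that less compound is needed. Compound 1 `CCCCc1nc(C)c(CC(=O)N(CC)CC)c(=O)n1Cc1ccc(-c2ccccc2-c2nnn[nH]2)cc1` gives 0.089 mg/kg in this assay, and compound 2 `CCCCc1nc(C)c(CC(=O)N2CCCC2)c(=O)n1Cc1ccc(-c2ccccc2-c2nnn[nH]2)cc1` gives 0.056 mg/kg. Among these two numbers compound 2 stands lowest, but the only step between them, a 1.6-fold lower number from compound 1 to compound 2 (0.20 log units; within the scatter), is within the scatter, so the two cannot be set in order.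

Compound 3 `CCCCc1nc(C)c(CCC(=O)N2CC(C)OC(C)C2)c(=O)n1Cc1ccc(-c2ccccc2-c2nnn[nH]2)cc1` has not yet been measured. It differs from compound 2 by ((2,6-dimethylmorpholin-4-yl)carbonyl)methyl in place of (pyrrolidin-1-yl)carbonyl on a saturated chain carbon bound to an aromatic carbon. For the measured compounds named here, the one measured step bears on it only in part: it shows that swapping one amine on the carbonyl for another left the number essentially unchanged, as a 1.6-fold lower number from compound 1 to compound 2 (0.20 log units; within the scatter) records. Going by the values given here, the change to compound 3 is larger, since the amide is both set on a longer chain and fitted with a different ring, and no measured pair speaks to that extension. The expectation for compound 3 is therefore a step of a 1.4-fold higher number from compound 2 to compound 3 (0.15 log units; within the scatter), with no confident direction and a wide range. Compound 3 is estimated to give 0.08 mg/kg in this assay, in a range from 0.025 mg/kg to 0.25 mg/kg.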

Compound 3, dose for half-maximal effect: 0.228 mg/kg
Compound 3: the middle estimate sits 2.9-fold (0.45 log units) below what was measured; the range from low to high includes it.
By their numbers in this assay, from the lowest: compounds 2 and 1 (each within the scatter of the next); then compound 3.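

In this assay, for the compounds shown here, this change at the saturated chain carbon bound to an aromatic carbon yields the only steps beyond the scatter in the set: ((2,6-dimethylmorpholin-4-yl)carbonyl)methyl in place of (pyrrolidin-1-yl)carbonyl gives a 4.1-fold higher number from compound 2 to compound 3 (0.61 log units; beyond the scatter) and, in place of diethylcarbamoyl, the same group gives a 2.6-fold higher number from compound 1 to compound 3 (0.41 log units; beyond the scatter) in a modest rise. The exchange of one amine for another on the shorter chain had left the number within the scatter, whereas this larger change, read one bond further out as ((pyrrolidin-1-yl)carbonyl)methyl to 2-((2,6-dimethylmorpholin-4-yl)carbonyl)ethyl, does raise the dose required. No measurement at hand bears on the cause of this rise.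

The compounds shown leave open whether the longer chain or the new ring carries the rise, as the two differ together here; a pyrrolidin-1-yl amide on the longer chain would separate them. They also leave open what the two methyl groups on the ring contribute, which an unsubstituted morpholin-4-yl amide on the same chain would address.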